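Acyl exchange at the amide of compound 1

The source may report more compounds than this note shows. Statements on the series, on what has been measured and on what is new or still open speak of the compounds shown alone.

In a functional assay on KYSE-450 cells (Homo sapiens) for inhibition, read by MTT assay, with a stated time of 48 h (on this read-out lower numbers stand for stronger inhibition and higher numbers for weaker inhibition), compound 1 `COCC(=O)N(Cc1ccc(OC)c(O)c1)c1cc(OC)c(OC)c(OC)c1` holds the lowest of the two numbers, at 460 nM. Compound 3 `C/C=C/C(=O)N(Cc1cccc(O)c1)c1cc(OC)c(OC)c(OC)c1` gives 14700 nM in this assay, a gap beyond the scatter, but the two structures differ in more than one place and only their values can be set side by side. Compound 2 `COc1cc(NCc2ccc(Cl)cc2)cc(OC)c1OC` reaches only a limit in this assay, namely > 80000 nM (the limit of > 80000 nM in this assay, at which 1 of the 3 values shown sits). Compound 4 `COc1ccc(CN(C(=O)C(C)C)c2cc(OC)c(OC)c(OC)c2)cc1O` is not yet measured; it differs from compound 1 by isopropyl in place of methoxymethyl on a carbonyl carbon. Among the measured compounds shown here, no measured step of this kind exists in the set. For compound 4 the step of a 1.3-fold higher number from compound 1 to compound 4 (0.12 log units; within the scatter) is expected to stay within the usual scatter, with no firm direction. Compound 4 is estimated at 600 nM, between 150 nM and 2500 nM.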

Compound 4, half-maximal inhibitory concentration: 390 nM
Compound 4: the middle estimate sits 1.5-fold (0.19 log units) above what was measured, and the stated range covers the measured number.
By their numbers in this assay, from the lowest: compounds 4 and 1 (each within the scatter of the next); then compound 3. At a limit, above all of these: compound 2.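

At the acyl position of the shared core, this assay gives the first measured step: a 1.2-fold lower number from compound 1 to compound 4 (0.07 log units; within the scatter) and so no change beyond the scatter. Methoxymethyl carries a hydrogen-bond acceptor and isopropyl carries none, so that ether oxygen is not required on the carbonyl carbon to hold a value at this level. No measured property on hand bears on this step.

Still open, going by these compounds, is whether a longer chain, such as n-butyl, or a ring, such as cyclopropyl, on the carbonyl carbon holds this level. On these data alone, an amine or a carboxylic acid at the end of that acyl chain is equally open.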